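A few compounds are considered here, and "the series" means these few. Any claim that something is new, unique, unknown or untested is made for them only; others in the source may bear on it.

- Compound 1 `CCC1=C(C(=O)OCC2CCCCC2)C(c2cccc(O)c2)NC(=O)N1` gives > 10000 nM (a limit)
- Compound 2 `CCC1=C(C(=O)OCC2CCCCC2)C(c2cccc(N)c2)NC(=O)N1` gives > 10000 nM (a limit)

In an ADME assay on CEMx174 cells (Homo sapiens) for cytotoxicity (a higher number here means that more compound is tolerated, a lower number that less compound is tolerated), compound 2 stands at > 10000 nM, which is a limit and not a number. Both measured compounds sit at the same limit: the limit of > 10000 nM in this assay, at which 2 of the 2 values shown sit. Compound 3 `CCC1=C(C(=O)OCC2CCCCC2)C(c2ccc(N)cc2)NC(=O)N1` differs from compound 2 as follows: 4-aminophenyl in place of 3-aminophenyl on a saturated ring carbon. In words, it carries 4-aminophenyl in place of 3-aminophenyl on a saturated ring carbon. Within the data shown here, the one measured step that bears on this is a step that the two limits leave unreadable from compound 1 to compound 2, so it offers no size to carry over. No step beyond the scatter is expected, and the estimated step is a step that the limit leaves unreadable from compound 2 to compound 3. For compound 3 the expected value is 15000 nM, with an estimated range from 7000 nM to 40000 nM.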

Compound 3, half-maximal cytotoxic concentration: > 10000 nM
Compound 3 ended at the assay's limit (the forecaster's own chance of this, stated with the estimate: 85%); the middle value lies beyond the limit too.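

No step can be read among compound 1, compound 2 and compound 3, because each value is a limit: the limit of > 10000 nM in this assay, at which 3 of the 3 values shown sit.

The compounds shown leave open where each true cytotoxic concentration lies, and whether 3-hydroxyphenyl, 3-aminophenyl or 4-aminophenyl makes any difference to it.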